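This account rests on a few compounds, and the source may have more. Where it says the series, first, only, none or still open, it means among the compounds named here.

Measured in a functional assay on BaF3 cells (Mus musculus) for inhibition, read by CCK-8 assay, with a stated time of 72 h; on this read-out higher numbers stand for weaker inhibition of growth and lower numbers for stronger inhibition of growth:
- Compound 1 `CNc1cc(Oc2ccc(NC(=O)Nc3ccc(C)c(C(F)(F)F)c3)cc2)ncn1` gives > 10000 nM (a limit)
- Compound 2 `CC(=O)Nc1cc(Oc2ccc(NC(=O)Nc3ccc(C)c(C(F)(F)F)c3)cc2)ncn1` gives 3230 nM
- Compound 3 `CNCCN(C)c1cc(Oc2ccc(NC(=O)Nc3ccc(C)c(C(F)(F)F)c3)cc2)ncn1` gives > 10000 nM (a limit)

Compound 3 gives no number, only (the limit of > 10000 nM in this assay, at which 2 of the 3 values shown sit). Compound 4 `Cc1ccc(NC(=O)Nc2ccc(Oc3cc(NCCN)ncn3)cc2)cc1C(F)(F)F` differs from it by one change: (2-aminoethyl)amino in place of methyl(2-(methylamino)ethyl)amino on an aromatic carbon. Going by the values given here, no measured step makes this exact exchange. The closest comparison is a step that the two limits leave unreadable from compound 1 to compound 3, and it gives no usable size. Among the compounds with values here, the only readable steps, an at least 3.0-fold lower number from compound 1 to compound 2 (0.49 log units; beyond the scatter) and an at least 3.0-fold higher number from compound 2 to compound 3 (0.49 log units; beyond the scatter), both turn on the acetamido group, which compound 4 lacks. Nothing therefore points to a clear gain, and the result is expected to lie close to the limit or to stay at it. The expected change is an at least 1.2-fold lower number from compound 3 to compound 4 (0.09 log units; that floor lies within the scatter), an estimate that the limit keeps loose. For compound 4 the estimated value is 8000 nM, with an expected range from 2500 nM to 20000 nM.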

Compound 4, concentration for 50% growth inhibition: > 10000 nM
Compound 4: no number, only a limit; the forecaster's own chance of this, stated with the estimate: 55%; middle value at least 1.2-fold (0.09 log units) away from the limit.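

In this assay, 2-aminoethyl in place of acetyl on the nitrogen gives an at least 3.0-fold higher number from compound 2 to compound 4 (0.49 log units; beyond the scatter), so a second chain ending in an amine also falls short of the acetamido group of compound 2. (2-aminoethyl)amino in place of methyl(2-(methylamino)ethyl)amino on this aromatic carbon brings no readable gain. Of the compounds shown only compound 2 gives a number rather than a limit. The steps from compound 3 and from compound 1 to compound 4 cannot be read, and most of the set now rests on one limit: the limit of > 10000 nM in this assay, at which 3 of the 4 values shown sit.

As far as these compounds go, it remains open whether an acyl group other than acetyl, such as propionyl or cyclopropanecarbonyl, would lower the number further on this nitrogen. Also open, from the compounds shown here alone, is how a morpholine or a piperazine would read at this position.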